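This account rests on a few compounds, and the source may have more. Where it says the series, first, only, none or still open, it means among the compounds named here.

Measured compounds in a functional assay on the whole organism with Canis familiaris (Canis lupus familiaris) as the target (on this read-out lower numbers stand for an effect already at smaller amounts and higher numbers for an effect only at larger amounts of compound), are these.

- compound 1 `Nc1nc(SCC(O)CN2CCN(C(c3ccc(F)cc3)c3ccc(F)cc3)CC2)c2[nH]cnc2n1` gives 0.85 mg/kg
- compound 2 `CC(=O)OC(CSc1[nH]cnc2ncnc1-2)CN1CCN(C(c2ccc(F)cc2)c2ccc(F)cc2)CC1` gives 0.3 mg/kg
- compound 3 `OC(CNc1[nH]cnc2ncnc1-2)CN1CCN(C(c2ccc(F)cc2)c2ccc(F)cc2)CC1` gives 0.28 mg/kg

Compound 3 lies within the scatter of compound 2 and clearly apart from compound 1. The next change leads to compound 4 `CC(=O)OC(CNc1[nH]cnc2ncnc1-2)CN1CCN(C(c2ccc(F)cc2)c2ccc(F)cc2)CC1`, with hydroxy going to acetoxy: acetyl in place of hydrogen on an oxygen on a saturated carbon. This places acetyl in place of hydrogen on an oxygen on a saturated carbon.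

Among the measured compounds shown here, the only measured step, a 3.0-fold lower number from compound 1 to compound 3 (0.48 log units; beyond the scatter), is modest, but it concerns a different place and says nothing direct about the oxygen. For the measured compounds named here, no measured pair isolates this change, since compound 2 has no hydroxy partner. Still, compound 2 carries the acetoxy group and gives 0.3 mg/kg, within the scatter of compound 3 at 0.28 mg/kg. In this assay the expected result is therefore no shift beyond the scatter, and the estimated step is a 1.1-fold higher number from compound 3 to compound 4 (0.03 log units; within the scatter). For compound 4 the estimated value is 0.3 mg/kg, with an expected range of 0.12 mg/kg to 0.75 mg/kg.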

Compound 4, dose for half-maximal effect: 0.27 mg/kg
Compound 4: middle estimate off by 1.1-fold (0.05 log units), on the high side; measured number inside the range.
By their numbers in this assay, from the lowest: compounds 4, 3 and 2 (each within the scatter of the next); then compound 1.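

In this assay, among the compounds shown here, the pair of compound 3 and compound 4 isolates the oxygen for the first time: acetyl in place of hydrogen gives a 1.0-fold lower number from compound 3 to compound 4 (0.02 log units; within the scatter), so hydroxy and acetoxy cannot be told apart at this position. With acetoxy held constant, exchanging the sulfur-containing group of 10 heavy atoms for the group of 5 carbon and 5 nitrogen atoms gives a 1.1-fold lower number from compound 2 to compound 4 (0.05 log units; within the scatter), so this exchange also leaves the two compounds within the scatter. No measurement bearing on the reason for either result is available.

Still open, from the compounds shown here alone, is whether a longer acyl chain such as pivaloyl, a methyl ether or an amine at this place would also stay within the scatter of compound 3. Going by these compounds, the effect of the same acetyl change on the core of compound 1 also remains open.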